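A few compounds are considered here, and "the series" means these few. Any claim that something is new, unique, unknown or untested is made for them only; others in the source may bear on it.

Within the data shown here, in a functional assay for inhibition, with Rattus norvegicus as the target (a lower number here means a stronger inhibitor, a higher number a weaker inhibitor), only two compounds have been tested so far. Compound 1, `CC(/N=c1\c(O)c(O)\c1=N/c1ccc(-n2ccnc2)cc1)C(C)(C)C`, gives > 30000 nM, which is a limit and not a number. Among the measured compounds shown here, compound 2, `Cc1cc(C#N)ccc1/N=c1\c(O)c(O)\c1=N/[C@H](C)C(C)(C)C`, gives 1080 nM, the only true number available, so it is the single firm reference point. Compound 3, `COc1cc(C#N)ccc1/N=c1\c(O)c(O)\c1=N/[C@H](C)C(C)(C)C`, differs from compound 2 in one group: methoxy in place of methyl on an aromatic carbon. This is methoxy in place of methyl on an aromatic carbon, ortho to a large group and meta to a cyano group. For the measured compounds named here, no measured pair shows this swap, so the data offer no direct guide to its effect. In this assay, a step no larger than the usual scatter is therefore expected, with neither direction favoured. The expected value for compound 3 is 1000 nM, with an estimated range from 300 nM to 3500 nM.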

Compound 3, half-maximal inhibitory concentration: 290 nM
The estimate for compound 3 lay 3.4-fold (0.54 log units) above the measured number; the whole stated range lies above it.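

Methoxy in place of methyl gives a 3.7-fold lower number from compound 2 to compound 3 (0.57 log units; beyond the scatter) in this assay and so shows that this aromatic carbon, ortho to a large group and meta to a cyano group, responds to the group placed on it. Among these compounds, no earlier pair of compounds offered any reading at this position, and this first reading points toward a stronger inhibitor from a change of only one added oxygen atom and no ring. Among the compounds shown here, nothing measured so far gives a reason for this step.

The compounds shown leave open whether a longer ether such as ethoxy, a chlorine atom or an amine on this same carbon would lower the number further or raise it again. They also leave open whether methoxy here would give a similar step if the other end of the shared core carried a different group.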